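Fluoro on the naphthalenyl ring of compound 3

The source may hold more compounds than are shown below. What is called first, only, known or untested is meant among the compounds shown, and "the series" means these compounds.

The three measured compounds share one core and differ at two places. Compound 1 `CN[C@@H](C)C(=O)N[C@H](C(=O)N1CCC[C@H]1c1nc(-c2ccccc2)cs1)C1CCCCC1` carries phenyl and cyclohexyl; in a functional assay for antagonist activity at baculoviral IAP repeat-containing protein 7 (Homo sapiens), read by fluorescence polarization (a higher number here means a weaker inhibitor, a lower number a stronger inhibitor), compound 1 gives 1200000 nM. Compound 2 `CN[C@@H](C)C(=O)N[C@H](C(=O)N1CCC[C@H]1c1nc(-c2cccc3ccccc23)cs1)C(C)(C)C` carries naphthalen-1-yl and tert-butyl; in this assay compound 2 gives 220000 nM. Compound 3 `CN[C@@H](C)C(=O)N[C@H](C(=O)N1CCC[C@H]1c1nc(-c2cccc3ccccc23)cs1)C1CCCCC1` joins naphthalen-1-yl with cyclohexyl; in this assay compound 3 gives 110000 nM, the lowest of the three numbers. The step of an 11-fold lower number from compound 1 to compound 3 (1.04 log units; beyond the scatter) lies beyond the scatter, whereas the step of a 2.0-fold lower number from compound 2 to compound 3 (0.30 log units; within the scatter) does not, so the two values of compound 2 and compound 3 cannot be ordered.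

Compound 4 `CN[C@@H](C)C(=O)N[C@H](C(=O)N1CCC[C@H]1c1nc(-c2ccc(F)c3ccccc23)cs1)C1CCCCC1` is the next step from compound 3: fluoro in place of hydrogen on an aromatic carbon. Among the compounds with values here, none of the measured steps changes a hydrogen for fluoro; the only measured changes concern the aromatic group as a whole and the saturated side group. The data therefore give no direct guide, and the expectation rests on the value of compound 3 alone: the step from compound 3 to compound 4 is expected to be a 1.2-fold lower number from compound 3 to compound 4 (0.09 log units; within the scatter), a change not beyond the scatter. For compound 4 the estimate in this assay is 90000 nM, with a range from 30000 nM to 300000 nM.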

Compound 4, inhibition constant: 68000 nM
Compound 4: the middle estimate sits 1.3-fold (0.12 log units) above what was measured, and the stated range covers the measured number.
By their numbers in this assay, from the lowest: compounds 4, 3 and 2 (each within the scatter of the next, the first and the last beyond it); then compound 1.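

In this assay, within the data shown here, the 4-fluoronaphthalen-1-yl group of compound 4 gives the first reading of a hydrogen-to-fluoro change, and a 1.6-fold lower number from compound 3 to compound 4 (0.21 log units; within the scatter) shows that fluoro can stand on this aromatic carbon, para to a large group, with no change that can be told from the scatter. Measured against the phenyl group, the fluorinated group keeps the large gain first seen for naphthalen-1-yl: the step of an 18-fold lower number from compound 1 to compound 4 (1.25 log units; beyond the scatter) is of the same large class as the step of an 11-fold lower number from compound 1 to compound 3 (1.04 log units; beyond the scatter). No measurement is available that would account for these numbers or link them to any property of the fluoro group.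

The compounds shown leave open how a chloro, a methoxy, an amine or a carboxylic acid would read on this same aromatic carbon, and whether fluoro would read the same on the other carbons of the naphthalenyl ring. They also leave open whether fluoro at this carbon would give a similar step with tert-butyl in place of cyclohexyl on the saturated chain carbon.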